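The source may report more compounds than this note shows. Statements on the series, on what has been measured and on what is new or still open speak of the compounds shown alone.

Measured compounds:
compound 1, `CCOc1ccc(C(=O)/C=C/c2ccc(C(F)(F)F)cc2)cc1`: 210 nM
compound 2, `O=C(/C=C/c1ccc(Br)cc1)c1ccc(-n2ccnc2)cc1`: 320 nM

In an assay on isolated protein for inhibition of Amine oxidase [flavin-containing] B (Homo sapiens) (on this read-out higher numbers stand for weaker inhibition and lower numbers for stronger inhibition), compound 1 gives 210 nM. In this assay compound 2 gives 320 nM. Of the two numbers, that of compound 2 is the one nearest the weak end, but its distance from compound 1 lies within the usual scatter, so the two compounds cannot be separated on these data; neither is called the stronger inhibitor here.

The next compound, compound 3, `O=C(/C=C/c1ccc(C(F)(F)F)cc1)c1ccc(-n2ccnc2)cc1`, is derived from compound 2 by trifluoromethyl in place of bromo on an aromatic carbon. Going by the values given here, no measured pair isolates this change, so its size is unknown. Among the compounds with values here, the one anchor is compound 1, which carries the same trifluoromethyl on that ring and, with a different group on the other ring, gives 210 nM. On that basis the step from compound 2 to compound 3 in this assay is expected to be small, a 1.2-fold lower number from compound 2 to compound 3 (0.09 log units; within the scatter), and not beyond the scatter in either direction. For compound 3 in this assay the estimate is 260 nM, within a range of 110 nM to 600 nM.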

Compound 3, half-maximal inhibitory concentration: > 10000 nM
Compound 3 gave a limit, no number; the forecaster's own chance of this, stated with the estimate: 3%; middle value at least 38-fold (1.58 log units) from the limit.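

In this assay compound 3 stands as a limit and not a number: the limit of > 10000 nM in this assay, at which 1 of the 3 values shown sits. Going by these compounds alone, with 1H-imidazol-1-yl on the other ring, this position, para to a large group, does not accept every exchange of one group for another: trifluoromethyl in place of bromo gives an at least 31-fold higher number from compound 2 to compound 3 (1.49 log units; beyond the scatter), a large step of which the earlier compounds gave no sign. Neither group accounts for this alone, as trifluoromethyl paired with ethoxy and bromo paired with 1H-imidazol-1-yl both give measurable values, while 1H-imidazol-1-yl in place of ethoxy with trifluoromethyl held constant gives an at least 47-fold higher number from compound 1 to compound 3 (1.67 log units; beyond the scatter), so within these three compounds the two places do not act independently.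

The full size of both steps stays open, as each rests on a limit, and no cause for them can be read from these data. Also open, going by these compounds, is whether a chlorine, a methyl or a nitrile at this position keeps inhibition with 1H-imidazol-1-yl on the other ring, and whether bromo paired with ethoxy reads as compound 1 does.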